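Alkyne cap variation on a shared amide core: efficacy notes

A few compounds are considered here, and "the series" means these few. Any claim that something is new, unique, unknown or untested is made for them only; others in the source may bear on it.

Measured so far:
- compound 1, `C[C@@H](NC(=O)c1ccc(C#Cc2ccccc2)cn1)C(C)(C)O`: 60.9%
- compound 2, `C[C@@H](NC(=O)c1ccc(C#Cc2ccc(F)cc2)cn1)C(C)(C)O`: 66.2%
- compound 3, `C[C@@H](NC(=O)c1ccc(C#CC2CC2)cn1)C(C)(C)O`: 63.4%

All three numbers come from a functional assay on HEK293 cells for positive allosteric modulation of metabotropic glutamate receptor 5 (Rattus norvegicus), read by fluorescence and calcium flux; on this read-out higher numbers stand for larger maximal responses and lower numbers for smaller maximal responses. The change a number 5.3 percentage points higher from compound 1 to compound 2 (within the scatter) and the change a number 2.5 percentage points higher from compound 1 to compound 3 (within the scatter) both stay inside the scatter, as does a number 2.8 percentage points lower from compound 2 to compound 3 (within the scatter). Compound 3 therefore sits second of the three numbers, with compound 1 nearest and compound 2 furthest, and neither gap is large enough to be called a difference. The cap on the triple-bonded carbon, whether phenyl, 4-fluorophenyl or cyclopropyl, has so far left the maximal response essentially unchanged.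

Compound 4, `C[C@@H](NC(=O)c1ccc(C#Cc2ncccc2F)cn1)C(C)(C)O`, differs from compound 3 by 3-fluoropyridin-2-yl in place of cyclopropyl on a triple-bonded carbon. Among the measured compounds shown here, the steps that bear on this are the two exchanges at the same triple-bonded carbon, a number 2.5 percentage points higher from compound 1 to compound 3 (within the scatter) and a number 2.8 percentage points lower from compound 2 to compound 3 (within the scatter), both within the scatter; no aromatic ring with a ring nitrogen has yet been measured at this position. Compound 4 is therefore expected to show no step beyond the scatter, a number 0.4 percentage points lower from compound 3 to compound 4 (within the scatter), and its value in this assay is estimated at 63%, with a range from 50% to 76%.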

Compound 4, largest response reached (reported as efficacy), in percent of the reference or control that the assay uses: 60.6%
For compound 4 the middle estimate is 2.4 percentage points above the measured one, within the range that was stated.
By their numbers in this assay, from the lowest: compounds 4, 1, 3 and 2 (each within the scatter of the next).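

Among the compounds shown here, with 3-fluoropyridin-2-yl on the triple-bonded carbon, a ring nitrogen and a hydrogen-bond acceptor enter this position for the first time, yet this assay shows no exchange beyond the scatter, whether against cyclopropyl (a number 2.8 percentage points lower from compound 3 to compound 4 (within the scatter)), 4-fluorophenyl (a number 5.6 percentage points lower from compound 2 to compound 4 (within the scatter)) or phenyl (a number 0.3 percentage points lower from compound 1 to compound 4 (within the scatter)). The position has now held a small carbocycle, two benzene-type caps and a fluorinated pyridine, and all of these exchanges stay within the scatter on maximal response. Nothing available explains why this read-out stays so flat across these caps.

Open, on these data alone, is whether a cap carrying a primary amine or a carboxylic acid would give a step beyond the scatter. Also open, as far as these compounds go, is whether a longer alkyl chain on the triple-bonded carbon would do so.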